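The source may report more compounds than this note shows. Statements on the series, on what has been measured and on what is new or still open speak of the compounds shown alone.

In a functional assay on the whole organism (strain albino) with Mus musculus as the target, at a dose of 100 mg/kg by the intraperitoneal route (on this read-out lower numbers stand for less inhibition and higher numbers for more inhibition at the one dose given (going by the name of the read-out)), compound 2 `O=C(Nc1ccc([N+](=O)[O-])cc1)Nn1c(-c2ccccc2)nc2ccccc2c1=O` gives 42%, the second highest of three numbers, though its gap to compound 1 is within the scatter. Compound 1 `CCc1nc2ccccc2c(=O)n1NC(=O)Nc1ccc([N+](=O)[O-])cc1` gives 41% and compound 3 `CCc1ccc(NC(=O)Nn2c(CC)nc3ccccc3c2=O)cc1` gives 58%. The step of a number 1 percentage points higher from compound 1 to compound 2 (within the scatter) lies on a different part of the molecule. Compound 4 `O=C(Nc1ccc(Br)cc1)Nn1c(-c2ccccc2)nc2ccccc2c1=O` differs from compound 2 by bromo in place of nitro on an aromatic carbon. Among the compounds with values here, the one measured step that bears on this change, at the same aromatic carbon, is a number 17 percentage points higher from compound 1 to compound 3 (beyond the scatter), where another group took the place of nitro. Compound 4 is therefore expected to show a modest rise, a number 10 percentage points higher from compound 2 to compound 4 (within the scatter), in this assay. The estimate for compound 4 is 52%, with a range from 38% to 66%.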

Compound 4, a percentage reported as inhibition, in the whole organism at one dose (the size of the read-out at that dose, not a potency): 58%
Estimate against measurement, compound 4: 6 percentage points below, within the range that was stated.
By their numbers in this assay, from the lowest: compounds 1 and 2 (each within the scatter of the next); then compounds 3 and 4 (each within the scatter of the next).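

In this assay the step of a number 16 percentage points higher from compound 2 to compound 4 (beyond the scatter) shows that, with phenyl on the shared core, replacing nitro at this place gives a rise beyond the scatter. The earlier step of a number 17 percentage points higher from compound 1 to compound 3 (beyond the scatter) showed this only for ethyl entering on the ethyl-bearing compound, so two different groups entering at this carbon on two different cores now both give such a rise. Nothing at hand explains the rise. From the compounds shown here alone, whether an amine or a carboxylic acid at this carbon would also give a rise stays open. So does what bromo would do on compound 1.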